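Fluoro to hydrogen on the pendant aromatic ring

This account rests on a few compounds, and the source may have more. Where it says the series, first, only, none or still open, it means among the compounds named here.

Of the compounds shown here, two of the shared core have been measured in a functional assay, tested at 50 ug/mL; on this read-out lower numbers stand for a weaker effect and higher numbers for a stronger effect at the one concentration tested. Compound 1 `Cc1ccc(C2C(C#N)=C(N)OC(c3c[nH]c4ccccc34)=C2C#N)cc1` gives 5.2%. Compound 2 `N#CC1=C(N)OC(c2c[nH]c3ccccc23)=C(C#N)C1c1ccc(F)cc1` gives 8.4%. Going by the values given here, the only measured step, a number 3.2 percentage points higher from compound 1 to compound 2 (within the scatter), is within the scatter, so the two numbers cannot be told apart; both read as weak effects at the concentration tested.

Compound 3 `N#CC1=C(N)OC(c2c[nH]c3ccccc23)=C(C#N)C1c1ccccc1` is not yet measured. It differs from compound 2 by hydrogen in place of fluoro on an aromatic carbon. Among the compounds with values here, the one measured step that bears on this position, a number 3.2 percentage points higher from compound 1 to compound 2 (within the scatter), was small and within the scatter, so an exchange of one small group for another at this aromatic carbon has so far left the read-out unmoved. On that basis no step beyond the scatter is expected from compound 2 to compound 3 in this assay, in either direction; the expected step is a number 2.4 percentage points lower from compound 2 to compound 3 (within the scatter).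

For compound 3 the estimate in this assay is 6%, with a range from 0% to 16%, pending the measurement.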

Compound 3, a percentage reported as activity, at one concentration (the size of the read-out at that concentration, not a potency): 14.4%
Compound 3: middle estimate off by 8.4 percentage points, on the low side; measured number inside the range.
By their numbers in this assay, from the lowest: compounds 1, 2 and 3 (each within the scatter of the next).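

Working notes on the position: with compound 3 the series now holds the bare phenyl as well as two substituted rings, so this aromatic carbon has been read with no substituent, not only with one small group exchanged for another. In this assay, the change from 4-fluorophenyl to phenyl gives a number 6 percentage points higher from compound 2 to compound 3 (within the scatter) and the removal of the methyl group gives a number 9.2 percentage points higher from compound 1 to compound 3 (within the scatter), so neither fluoro nor methyl can be told apart from hydrogen here, and all three compounds remain weak at the one concentration tested. No measurement available here accounts for these numbers.

Still open, as far as these compounds go, is whether a group of a different kind on this aromatic carbon, such as an amine, a carboxylic acid or a longer chain such as a butyl group, would give a step beyond the scatter in this assay. All three compounds also share the rest of the core unchanged, so these numbers say nothing about how a carboxylic acid in place of either nitrile would read.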